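Fluorine on a Shared Core Across Two Isomers

The source may hold more compounds than are shown below. What is called first, only, known or untested is meant among the compounds shown, and "the series" means these compounds.

Compound 1 `COc1cccc2[nH]cc(C3(c4c[nH]c5cccc(OC)c45)C(=O)Nc4ccccc43)c12` and compound 2 `COc1ccc2c(C3(c4c[nH]c5cc(OC)ccc45)C(=O)Nc4ccccc43)c[nH]c2c1` are built from the same atoms joined differently; the difference between the two cores is not broken down here. In a functional assay on HepG2 cells (Homo sapiens) for cytotoxicity, read by MTT assay, with a stated time of 48 h (a higher number here means a weaker inhibitor, a lower number a stronger inhibitor), compound 1 gives 9000 nM, and in this assay compound 2 gives 12000 nM, so the two numbers lie within the scatter of each other and neither can be placed above the other.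

Compound 3 `COc1cccc2[nH]cc(C3(c4c[nH]c5cccc(OC)c45)C(=O)Nc4ccc(F)cc43)c12` is derived from compound 1 by a single change, (fluoro in place of hydrogen on an aromatic carbon). In this assay compound 3 gives 18000 nM. That change gave a 2.0-fold higher number from compound 1 to compound 3 (0.30 log units; within the scatter), so the two compounds cannot be told apart by this measurement.

Compound 4 `COc1ccc2c(C3(c4c[nH]c5cc(OC)ccc45)C(=O)Nc4ccc(F)cc43)c[nH]c2c1` has not yet been measured. Within the data shown here, it is derived from compound 2 by fluoro in place of hydrogen on an aromatic carbon, the same change at the same kind of place as the one that turned compound 1 into compound 3. Because the same change produced only a 2.0-fold higher number from compound 1 to compound 3 (0.30 log units; within the scatter) on the core of compound 1, a step of similar size is expected here: compound 4 is estimated to differ from compound 2 by a 1.5-fold higher number from compound 2 to compound 4 (0.18 log units; within the scatter). That expectation rests on one pair alone, so it is held loosely. For compound 4 the estimate in this assay is 18000 nM, with a range from 8000 nM to 40000 nM.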

Compound 4, half-maximal inhibitory concentration: 16000 nM
Beside the measured number, compound 4's estimate is 1.1-fold (0.05 log units) above it, and the stated range covers the measured number.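

On the second core, fluoro in place of hydrogen on an aromatic carbon gave a 1.3-fold higher number from compound 2 to compound 4 (0.12 log units; within the scatter) in this assay, so this pair cannot be told apart by this measurement. Set beside the earlier step, the same change shows no difference between the two cores: the same change on two cores in this assay, a 2.0-fold higher number (0.30 log units; within the scatter) from compound 1 to compound 3 and a 1.3-fold higher number (0.12 log units; within the scatter) from compound 2 to compound 4, 1.5-fold (0.18 log units) apart, within the scatter of two such steps. This shows only that, on these two isomeric cores, the change carries over without any step reaching beyond the scatter; it does not show that fluoro has a real effect on either core, since neither step can be separated from repeat-to-repeat variation, and two pairs in a single cell assay give no rule for any other core.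

The compounds shown leave open whether a different group on the same aromatic carbon, such as chloro, a nitrile or an amine, would move the number beyond the scatter on either core. They also leave open what would follow from replacing the amide hydrogen with a methyl group or a longer chain, and whether such a change would carry from one core to the other as closely as fluoro does here.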